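Swapping pyridin-2-yl for phenyl on compound 1

This account rests on a few compounds, and the source may have more. Where it says the series, first, only, none or still open, it means among the compounds named here.

Measured so far in an ADME assay on the whole organism (Mus musculus, strain CD-1) for pharmacokinetics, read by LC-MS, with a stated time of 7 h, at a dose of 20 mg/kg by the oral route; a lower number here means less compound in the circulation, a higher number more compound in the circulation at the dose given:
Compound 1 `CC(Sc1nc2c(cnn2C)c(=O)n1-c1ccccc1)c1ccccn1` gives 7300 nM
Compound 2 `CC(Sc1nc2nn(C3COC3)cc2c(=O)n1-c1ccccc1)c1ccccn1` gives 3900 nM

These two numbers lie within the usual scatter of each other, so compound 1 stands level with compound 2 in this assay for now. Two compounds are a thin basis for any trend.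

Compound 3 `CC(Sc1nc2c(cnn2C)c(=O)n1-c1ccccc1)c1ccccc1` keeps the rest of compound 1 and carries phenyl in place of pyridin-2-yl on a saturated chain carbon bound to a saturated chain carbon and a sulfur. Put simply, 1-(pyridin-2-yl)ethyl becomes 1-phenylethyl. Among the measured compounds shown here, no measured pair shows this swap, so the data give no direct guide to its size. The only yardstick is the narrow spread between compound 1 (7300 nM) and compound 2 (3900 nM), which argues for caution and a wide range. An expected 1.5-fold lower number from compound 1 to compound 3 (0.16 log units; within the scatter) would be a modest downward step that stays within the scatter. In this assay compound 3 is expected at 5000 nM within an estimated range of 1500 nM to 15000 nM for this compound.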

Compound 3, maximal plasma concentration: 800 nM
Estimate against measurement, compound 3: 6.3-fold (0.80 log units) above; measured number below the stated range.
By their numbers in this assay, from the lowest: compound 3; then compounds 2 and 1 (each within the scatter of the next).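

In this assay, the ring on a saturated chain carbon bound to a saturated chain carbon and a sulfur proves to matter: with the rest of the molecule unchanged, swapping pyridin-2-yl for phenyl gives a 9.1-fold lower number from compound 1 to compound 3 (0.96 log units; beyond the scatter). Both are six-membered aromatic rings with the same count of heavy atoms, and the only difference is that a ring nitrogen gives way to carbon, so a single-atom change at this place is enough to move the number beyond the usual scatter, something the earlier pair, which differs in more than one place, could not show. Nothing available explains why the maximal plasma concentration falls with this swap.

Among the compounds shown here, only two rings are compared at this place, so it remains open whether the ring nitrogen must sit where it does in pyridin-2-yl, a question that pyridin-3-yl or pyridin-4-yl could answer. Going by these compounds, it is also open whether a phenyl ring carrying an amine or a methoxy group would keep the low number of compound 3 or come back towards that of compound 1.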